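Cytotoxicity notes: from compound 3 to compound 4

The source may hold more compounds than are shown below. What is called first, only, known or untested is meant among the compounds shown, and "the series" means these compounds.

Values in an ADME assay on MT4 cells (Homo sapiens) for cytotoxicity, read by MTT assay, with a stated time of 5 days; on this read-out lower numbers stand for higher toxicity in this test and higher numbers for lower toxicity in this test (all three compounds):
compound 1 `CCCNc1cc(Oc2c(OC)cc3cc(C#N)ccc3c2OC)nc(Nc2ccc(C#N)cc2)n1` gives > 125000 nM (a limit)
compound 2 `COc1cc2cc(C#N)ccc2c(OC)c1Oc1cc(NC2CCOCC2)nc(Nc2ccc(C#N)cc2)n1` gives > 125000 nM (a limit)
compound 3 `COc1cc2cc(C#N)ccc2c(OC)c1Oc1cc(NCC(O)CO)nc(Nc2ccc(C#N)cc2)n1` gives 29500 nM (a number)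

Among the compounds with values here, compound 3 at 29500 nM holds the only number so far. The remaining evidence is the limit of > 125000 nM in this assay, at which 2 of the 3 values shown sit, and it gives no further number. Compound 4 `COc1cc2cc(C#N)ccc2c(OC)c1Oc1cc(NCCCCO)nc(Nc2ccc(C#N)cc2)n1` carries 3-hydroxypropyl in place of 1,2-dihydroxyethyl on a saturated chain carbon bound to a nitrogen on an aromatic ring and the same difference reads 2,3-dihydroxypropyl to 4-hydroxybutyl. Within the data shown here, two measured steps bear on this: an at least 4.2-fold lower number from compound 1 to compound 3 (0.62 log units; beyond the scatter) and an at least 4.2-fold lower number from compound 2 to compound 3 (0.62 log units; beyond the scatter) both end at the 2,3-dihydroxypropyl chain. Both sizes are bounds and neither step isolates this change, while a step that the two limits leave unreadable from compound 1 to compound 2 adds no size. In this assay the expected step is a 1.7-fold higher number from compound 3 to compound 4 (0.23 log units; within the scatter) with any drift expected towards a higher number. The estimate stays anchored on compound 3 at 29500 nM as the closest measured chain. For compound 4 the estimate is 50000 nM with an expected range of 15000 nM to 120000 nM.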

Compound 4, half-maximal cytotoxic concentration: 39100 nM
Compound 4: the middle estimate sits 1.3-fold (0.11 log units) above what was measured; the range from low to high includes it.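

In this assay, a 1.3-fold higher number from compound 3 to compound 4 (0.12 log units; within the scatter), so a measured toxicity number at this place does not depend on the 1,2-dihydroxyethyl group: 3-hydroxypropyl, with 1 hydrogen-bond donor in place of 2, reads alike. The hydroxyl-bearing chain now stands apart from the two chains without a hydroxyl in two readings, an at least 3.1-fold lower number from compound 1 to compound 4 (0.50 log units; beyond the scatter) and an at least 3.1-fold lower number from compound 2 to compound 4 (0.50 log units; beyond the scatter), and among the four compounds neither compound 3 nor compound 4 goes against this. Both steps are bounds, since the other end of each is a limit and not a number: the limit of > 125000 nM in this assay, at which 2 of the 4 values shown sit.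

On these data alone, the true size of these steps stays open, as does whether the hydroxyl itself is what matters at the chain end. As far as these compounds go, it is also open whether a terminal amine, a carboxylic acid or a longer chain ending in hydroxyl would read with compound 4 or with compound 1.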